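Replacing 1H-indol-6-yl with thiophen-2-yl

The source may report more compounds than this note shows. Statements on the series, on what has been measured and on what is new or still open speak of the compounds shown alone.

Compound 1 `COc1cc(-c2nc3cccc(-c4cc(OC)c(OC)c(OC)c4)c3o2)ccc1O`: 10300 nM
Compound 2 `COc1cc(-c2cccc3nc(-c4ccc5cc[nH]c5c4)oc23)cc(OC)c1OC`: 300 nM

In a functional assay on U-251 cells (Homo sapiens) for antiproliferative activity, read by MTT assay, with a stated time of 48 h (a lower number here means a stronger inhibitor, a higher number a weaker inhibitor), compound 2 stands lowest of the two measured compounds, at 300 nM. Within the data shown here, the only measured step, a 34-fold lower number from compound 1 to compound 2 (1.54 log units; beyond the scatter), put 1H-indol-6-yl in place of 4-hydroxy-3-methoxyphenyl and was large, beyond the scatter. Compound 3 `COc1cc(-c2cccc3nc(-c4cccs4)oc23)cc(OC)c1OC` changes the same place again: thiophen-2-yl in place of 1H-indol-6-yl on an aromatic carbon. Among the measured compounds shown here, no compound carrying thiophen-2-yl has been measured, so this single step is the only guide. It shows that the number can move widely with the group at this place, and compound 2 holds the lower of the two values. A step beyond the scatter toward a higher number is therefore expected, though a smaller one than that measured step. The estimated change is a 5.0-fold higher number from compound 2 to compound 3 (0.70 log units; beyond the scatter). The estimate for compound 3 is 1500 nM, expected to lie within 300 nM to 8000 nM.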

Compound 3, half-maximal inhibitory concentration: 3000 nM
For compound 3 the middle estimate is 2.0-fold (0.30 log units) below the measured one; the range from low to high includes it.
By their numbers in this assay, from the lowest: compound 2; then compound 3; then compound 1.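

In this assay, the change of thiophen-2-yl for 1H-indol-6-yl gave a 10-fold higher number from compound 2 to compound 3 (1.00 log units; beyond the scatter), so most of what the indole had gained at this aromatic carbon was lost. The thiophene did not lose all of it, however: the replacement of 4-hydroxy-3-methoxyphenyl by thiophen-2-yl gave a 3.4-fold lower number from compound 1 to compound 3 (0.54 log units; beyond the scatter), which places this group between the other two and shows that a single five-membered aromatic ring can still improve on the substituted phenyl. No evidence is available to explain this order.

The step from the indole to the thiophene removes a six-membered aromatic ring and a hydrogen-bond donor together, and the compounds shown cannot separate the two. A 1H-pyrrol-2-yl group, which keeps the ring hydrogen on nitrogen without the six-membered ring, would bear on that question.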